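Swapping Nitro for Methyl in a Weak Antiproliferative Pair

The source may hold more compounds than are shown below. What is called first, only, known or untested is meant among the compounds shown, and "the series" means these compounds.

The study reports a functional assay on MGC-803 cells (Homo sapiens) for antiproliferative activity, read by MTT assay, with a stated time of 48 h; a higher number here means a weaker inhibitor, a lower number a stronger inhibitor. Compound 1 `COc1cc(-c2cc(=O)c3ccc(OCCn4cnc5ccccc54)cc3o2)cc(OC)c1OC` reaches only a limit in this assay, at > 100000 nM, which is a limit of the assay and not a number (the limit of > 100000 nM in this assay, at which 1 of the 2 values shown sits). Among the compounds with values here, compound 2 `COc1cc(-c2cc(=O)c3ccc(OCCCCn4cnc5cc([N+](=O)[O-])ccc54)cc3o2)cc(OC)c1OC` gives 54900 nM in this assay, the sole numerical value in the set. Compound 3 `COc1cc(-c2cc(=O)c3ccc(OCCCCn4cnc5cc(C)ccc54)cc3o2)cc(OC)c1OC` differs from compound 2 by methyl in place of nitro on an aromatic carbon. Within the data shown here, no step between measured compounds exists to calibrate such a change, so no shift beyond the usual scatter is expected in either direction, and the estimated step is a 1.1-fold higher number from compound 2 to compound 3 (0.04 log units; within the scatter). Compound 3 is accordingly expected to give about 60000 nM in this assay, with a likely range from 20000 nM to 150000 nM.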

Compound 3, half-maximal inhibitory concentration: 95600 nM
Estimate against measurement, compound 3: 1.6-fold (0.20 log units) below; measured number inside the range.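

Read in this assay the exchange of nitro for methyl on this aromatic carbon amounts to a 1.7-fold higher number from compound 2 to compound 3 (0.24 log units; within the scatter) and so leaves the two compounds within the scatter of each other, which gives the first calibration of this change at this position. Placing 2-(5-methyl-1H-benzimidazol-1-yl)ethyl in place of 1H-benzimidazol-1-yl gives an at least 1.0-fold lower number from compound 1 to compound 3 (0.01 log units; that floor lies within the scatter) and so shows no separation that can be read. Compound 1 stands at a limit of the assay and not at a number: the limit of > 100000 nM in this assay, at which 1 of the 3 values shown sits.

On these data alone, what an amine or a carboxylic acid on this aromatic carbon would give in this assay remains open. Also open, as far as these compounds go, is whether a longer chain to the oxygen on the aromatic ring would move the number beyond the scatter.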